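The source may report more compounds than this note shows. Statements on the series, on what has been measured and on what is new or still open speak of the compounds shown alone.

Going by the values given here, compound 1 `COc1ccc(-c2cnc3nc(N)nc(N4CCN(C(=O)COc5ccccc5)CC4)c3n2)cc1OC` is the stronger of the two compounds measured so far. In a functional assay on cells (T-cell, Homo sapiens) for inhibition (a higher number here means a weaker inhibitor, a lower number a stronger inhibitor), compound 1 gives 4 nM. Compound 2 `COc1ccc(-c2cnc3nc(N)nc(NCc4ccccc4)c3n2)cc1OC` in this assay gives 13000 nM, a far higher number, and the gap between the two lies well beyond the usual scatter. Compound 3 `COc1ccc(-c2cnc3nc(N)nc(N4CCN(Cc5ccccc5F)CC4)c3n2)cc1OC` has not yet been measured. It arises from compound 1 by a single change: 2-fluorobenzyl in place of (phenoxymethyl)carbonyl on an amine nitrogen in a ring. The group that leaves carries two hydrogen-bond acceptors, the group that enters carries none, while the six-membered non-aromatic ring with 2 nitrogen and the shared core stay. Among the compounds with values here, no measured pair shows a step of this kind, so its size can only be estimated. The expected step from compound 1 to compound 3 in this assay is a 7.5-fold higher number from compound 1 to compound 3 (0.88 log units; beyond the scatter), toward a weaker inhibitor. Compound 3 is thus expected to give about 30 nM, probably between 5 nM and 300 nM.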

Compound 3, half-maximal inhibitory concentration: 700 nM
Estimate against measurement, compound 3: 23-fold (1.37 log units) below, and the stated range ends below it.
By their numbers in this assay, from the lowest: compound 1; then compound 3; then compound 2.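

Going by these compounds alone, changing only the group on the amine nitrogen in the ring gives a 180-fold higher number from compound 1 to compound 3 (2.24 log units; beyond the scatter) in this assay, the first step here that can be tied to a single place. It shows that this position strongly affects the result while the shared core and the six-membered ring with 2 nitrogen stay the same. No available evidence explains the size of this step.

The leaving group differs from the entering one in several ways at once: it has a carbonyl and an ether oxygen, while 2-fluorobenzyl has a fluorine and neither of those features, so this pair cannot say which difference counts. Unsubstituted benzyl, 2-phenoxyethyl and phenylacetyl on the same nitrogen could help separate the roles of the fluorine, the carbonyl and the ether oxygen.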